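The compounds below may be only part of what the source reports. "The series", "measured", "known", "first", "only" and "open" are said of these compounds alone.

Measured compounds in an assay on isolated protein for inhibition of Aromatase (Homo sapiens), read by fluorescence, with a stated time of 30 min; on this read-out lower numbers stand for stronger inhibition and higher numbers for weaker inhibition: compound 1 `CC/C(=C(/c1ccc(O)cc1)c1ccc(OCCO)cc1)c1ccccc1` gives 30500 nM; compound 2 `CC/C(=C(/c1ccc(O)cc1)c1ccc(CCCN)cc1)c1ccccc1` gives 7340 nM; compound 3 `CC/C(=C(/c1ccc(O)cc1)c1ccc(OCCN)cc1)c1ccc(F)cc1` gives 1020 nM.

Compound 2 stands second highest of the three numbers in this assay. Within the data shown here, its nearest neighbour is compound 1, and the only single-point step in the set, a 4.2-fold lower number from compound 1 to compound 2 (0.62 log units; beyond the scatter), runs between them. Among the measured compounds shown here, compound 3 lies furthest from compound 2, with a lower number, but the two differ in more than one place and no single step joins them.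

Compound 4 `CC/C(=C(/c1ccc(O)cc1)c1ccc(CCCN)cc1)c1ccc(O)cc1` is not yet measured. It differs from compound 2 by hydroxy in place of hydrogen on an aromatic carbon. For the measured compounds named here, no measured step touches this position: the step from compound 1 to compound 2 concerns the chain on the other aromatic ring, and nothing in the set reports hydroxy for hydrogen on this phenyl. Going by the values given here, with no step bearing on the change, the expectation for compound 4 is a number close to that of compound 2, with a 1.3-fold lower number from compound 2 to compound 4 (0.13 log units; within the scatter) not expected to exceed the scatter. Compound 4 is therefore estimated at 5500 nM, within a range of 1500 nM to 20000 nM.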

Compound 4, half-maximal inhibitory concentration: 491 nM
The estimate for compound 4 lay 11-fold (1.05 log units) above the measured number; measured number below the stated range.
By their numbers in this assay, from the lowest: compound 4; then compound 3; then compound 2; then compound 1.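

On the phenyl ring of compound 2, in this assay, phenyl to 4-hydroxyphenyl gives a 15-fold lower number from compound 2 to compound 4 (1.17 log units; beyond the scatter), with the hydroxy para to a large group. Among these compounds, the only earlier single-place step concerned the chain on the other aromatic ring, so this is the first reading at this position, and it shows that this one added hydroxy alone moves the number well beyond the scatter. The data at hand offer nothing that accounts for the size of this step.

On these data alone, whether the step is particular to hydroxy stays open; methoxy, an amine or a carboxylic acid at the same place would test that. Also open, as far as these compounds go, is whether a similar step appears with the 2-hydroxyethoxy chain of compound 1 or with a longer chain on the other ring.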